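The compounds below may be only part of what the source reports. "The series", "measured", "known", "first", "only" and "open" are said of these compounds alone.

Measured in a functional assay on CCRF-CEM cells (Homo sapiens) for antiproliferative activity, with a stated time of 72 h; on this read-out lower numbers stand for stronger inhibition and higher numbers for weaker inhibition:
- Compound 1 `OC[C@H]1O[C@@H](n2cnc3c(NCc4cccc(Br)c4)ncnc32)[C@H](O)[C@@H]1O`: 5000 nM
- Compound 2 `COc1cccc(CNc2ncnc3c2ncn3[C@@H]2O[C@H](CO)[C@@H](O)[C@H]2O)c1OC`: > 166000 nM (a limit, not a number)

Compound 2 has no exact value on these numbers, only a limit: the limit of > 166000 nM in this assay, at which 1 of the 2 values shown sits. Compound 3 `COc1cc(CNc2ncnc3c2ncn3[C@@H]2O[C@H](CO)[C@@H](O)[C@H]2O)cc(OC)c1` carries 3,5-dimethoxyphenyl in place of 2,3-dimethoxyphenyl on a saturated chain carbon bound to a nitrogen on an aromatic ring. Within the data shown here, one measured step bears on this change, and only indirectly: an at least 33-fold higher number from compound 1 to compound 2 (1.52 log units; beyond the scatter), a large step that exchanged 3-bromophenyl for 2,3-dimethoxyphenyl. Among the measured compounds shown here, no measured step compares the two dimethoxyphenyl groups directly. A move to a lower number is expected in this assay, though compound 3 may also end at a limit. Compound 1, at 5000 nM, marks the expected lower end of that move. The expected step is an at least 2.7-fold lower number from compound 2 to compound 3 (0.44 log units; beyond the scatter). For compound 3 the estimated value is 60000 nM, with an expected range of 10000 nM to 166000 nM.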

Compound 3, half-maximal inhibitory concentration: > 166000 nM
Compound 3 ended at the assay's limit (the forecaster's own chance of this, stated with the estimate: 45%); at least 2.7-fold (0.44 log units) between middle value and limit.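

In this assay compound 3 gives > 166000 nM, which is a limit and not a number. Exchanging 3-bromophenyl for 3,5-dimethoxyphenyl gives an at least 33-fold higher number from compound 1 to compound 3 (1.52 log units; beyond the scatter), so a second dimethoxyphenyl group, with its two methoxy groups arranged differently, also yields no exact value. The step between compound 2 and compound 3 cannot be read, and no order can be given for the two dimethoxyphenyl groups, since both compounds stand at the same limit: the limit of > 166000 nM in this assay, at which 2 of the 3 values shown sit.

As far as these compounds go, how far either dimethoxyphenyl group lies past that limit remains open. Also open, from the compounds shown here alone, is whether a single methoxy group, or a chlorine atom in place of the bromine, would keep a value close to that of compound 1 at 5000 nM.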